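The compounds below may be only part of what the source reports. "The series", "measured", "known", "first", "only" and "open" are said of these compounds alone.

Of the compounds shown here, three have been tested in a functional assay on Caco-2 cells (Homo sapiens) for cytotoxicity, read by MTT assay, with stated times of 6 h and 48 h; on this read-out higher numbers stand for weaker inhibition and lower numbers for stronger inhibition. Compound 2 `Cn1c(/C=C/C(=O)c2ccc(O)cc2)cc(Br)c1Br` gives 6000 nM in this assay. Compound 1 `Cn1c(/C=C/C(=O)c2ccccc2)cc(Br)c1Br` differs from it by hydrogen in place of hydroxy on an aromatic carbon. In this assay compound 1 reaches only a limit of the assay, >= 100000 nM. The step is an at least 16-fold higher number from compound 2 to compound 1 (1.22 log units; beyond the scatter). Compound 3 `O=C(/C=C/c1cc(Br)c(Br)[nH]1)c1ccccc1O` likewise gives only a limit in this assay, >= 100000 nM. How the core of compound 3 differs from that of compound 2 is not broken down here.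

Compound 4 `O=C(/C=C/c1cc(Br)c(Br)[nH]1)c1ccccc1` has not yet been measured. It differs from compound 3 by hydrogen in place of hydroxy on an aromatic carbon. This is the same kind of change as that from compound 2 to compound 1, though the place is not identical: the hydroxy leaves para to a large group in the first case and ortho to a large group in the second. Inhibition is expected to remain weak, because the earlier change gave an at least 16-fold higher number from compound 2 to compound 1 (1.22 log units; beyond the scatter) and because compound 3 already sits at the limit of >= 100000 nM in this assay, at which 2 of the 3 values shown sit. The expected step is a step that the limit leaves unreadable from compound 3 to compound 4. Compound 4 is expected to give about 150000 nM in this assay, estimated between 60000 nM and 500000 nM, most likely again as a limit.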

Compound 4, half-maximal inhibitory concentration: >= 100000 nM
Compound 4: no number, only a limit; the forecaster's own chance of this, stated with the estimate: 90%; the middle value lies beyond the limit too.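

Compound 4 gives only a limit, as do compound 3 and compound 1, so neither the step from compound 3 to compound 4 nor the step from compound 1 to compound 4 can be read. The compounds shown leave open whether the hydroxy of compound 3 or the methyl on the aromatic nitrogen of compound 1 makes any difference in this assay, with most values resting at one point: the limit of >= 100000 nM in this assay, at which 3 of the 4 values shown sit.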